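Trifluoromethyl to methoxy in the series

The compounds below may be only part of what the source reports. "The series", "measured", "known", "first", "only" and "open" are said of these compounds alone.

Measured in a functional assay on MCF7 cells (Homo sapiens) for antiproliferative activity, read by MTT assay, with a stated time of 48 h; on this read-out higher numbers stand for weaker inhibition and lower numbers for stronger inhibition:
- compound 1 `Cc1ccc(-c2cc(NC(=O)/C=C/c3ccc(Cl)cc3)n[nH]2)cc1`: 1190 nM
- compound 2 `O=C(/C=C/c1ccc(Br)cc1)Nc1cc(-c2ccc(Br)cc2)[nH]n1`: 920 nM
- compound 3 `Cc1ccc(-c2cc(NC(=O)/C=C/c3ccc(C(F)(F)F)cc3)n[nH]2)cc1`: 720 nM

In this assay, compound 3 gives 720 nM, and its gaps to compound 1 and compound 2 stay within the scatter, so the three values cannot be ranked.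

The next compound is compound 4 `COc1ccc(/C=C/C(=O)Nc2cc(-c3ccc(C)cc3)[nH]n2)cc1`, with methoxy in place of trifluoromethyl on an aromatic carbon, para to a large group: methoxy in place of trifluoromethyl on an aromatic carbon.

Going by the values given here, only one measured step touches this place: a 1.7-fold lower number from compound 1 to compound 3 (0.22 log units; within the scatter), with trifluoromethyl in place of chloro. That step is small and does not leave the scatter. Among the compounds with values here, no measured compound carries methoxy, so the data offer no direct guide to this group. A step beyond the scatter in this assay is therefore not expected, though a slightly higher number is the tentative lean.

The estimated change is a 1.5-fold higher number from compound 3 to compound 4 (0.18 log units; within the scatter), which would stay within the scatter.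

For compound 4 the expected value is 1100 nM, with an estimated range of 450 nM to 2700 nM.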

Compound 4, half-maximal inhibitory concentration: 860 nM
Beside the measured number, compound 4's estimate is 1.3-fold (0.11 log units) above it, and the stated range covers the measured number.
By their numbers in this assay, from the lowest: compounds 3, 4, 2 and 1 (each within the scatter of the next).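

In this assay, the change to methoxy on this aromatic carbon, para to a large group, gives a 1.2-fold higher number from compound 3 to compound 4 (0.08 log units; within the scatter) and, set against chloro, a 1.4-fold lower number from compound 1 to compound 4 (0.14 log units; within the scatter) with both steps inside the scatter. Methoxy carries 1 hydrogen-bond acceptor and 2 heavy atoms, whereas trifluoromethyl carries 0 hydrogen-bond acceptors and 4 heavy atoms, yet this difference produces no readable separation at this place, and chloro, trifluoromethyl and methoxy cannot be ranked here. No supporting measurement bears on this result.

From the compounds shown here alone, whether an amine or a carboxylic acid at this place would move the number beyond the scatter remains open. Also open is whether the same lack of separation among these three groups would hold in other cell lines.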